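Triazole-linked sulfonamides against gastric cancer cells: a 3-chlorophenyl variant

The source may report more compounds than this note shows. Statements on the series, on what has been measured and on what is new or still open speak of the compounds shown alone.

Measured so far:
compound 1 `O=c1[nH]cc(S(=O)(=O)Nc2ccccc2-c2cn(-c3ccc(Cl)cc3)nn2)c(=O)[nH]1`: 2700 nM
compound 2 `O=c1[nH]cc(S(=O)(=O)Nc2ccc(-c3cn(-c4ccccc4F)nn3)cc2)c(=O)[nH]1`: 7270 nM

In a functional assay on SGC-7901 cells (Homo sapiens) for antiproliferative activity, read by MTT assay, with a stated time of 24 h (a higher number here means a weaker inhibitor, a lower number a stronger inhibitor), compound 2 gives 7270 nM, the highest of the two numbers to hand. Going by the values given here, compound 1 gives 2700 nM in this assay, a lower number that lies beyond the scatter; the two compounds differ in more than one place, so no single step is drawn between them.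

Compound 3 `O=c1[nH]cc(S(=O)(=O)Nc2ccc(-c3cn(-c4cccc(Cl)c4)nn3)cc2)c(=O)[nH]1` is not yet measured. It differs from compound 2 by 3-chlorophenyl in place of 2-fluorophenyl on an aromatic nitrogen. Among the compounds with values here, no measured pair shows this change on its own, so its size is unknown from the data. Compound 3 is expected to stay close to the value of compound 2, which gives 7270 nM in this assay. Compound 3 is estimated at 5500 nM, with a range of 2000 nM to 15000 nM. The step of a 1.3-fold lower number from compound 2 to compound 3 (0.12 log units; within the scatter) that this estimate means is expected to fall within the scatter, in no firm direction.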

Compound 3, half-maximal inhibitory concentration: 2460 nM
Estimate against measurement, compound 3: 2.2-fold (0.35 log units) above, and the stated range covers the measured number.
By their numbers in this assay, from the lowest: compounds 3 and 1 (each within the scatter of the next); then compound 2.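

The change to 3-chlorophenyl in place of 2-fluorophenyl on an aromatic nitrogen gives a 3.0-fold lower number from compound 2 to compound 3 (0.47 log units; beyond the scatter) in this assay, a modest step but the first in the series that can be read at a single place. This position therefore responds to the group it carries, even though the two groups match in heavy atom count, hydrogen-bond donors and acceptors, and net charge. No measurement at hand bears on the reason for this step.

The halogen and its place on the phenyl ring change together here, and the compounds shown do not separate the two. Also open, going by these compounds, is how this assay would read with an amine or a carboxylic acid on that phenyl ring, or with an unsubstituted phenyl at this position.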